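The source may hold more compounds than are shown below. What is called first, only, known or untested is meant among the compounds shown, and "the series" means these compounds.

Measured so far:
- Compound 1 `COc1cc(Nc2c(-c3ccc(Cl)cc3)nc3cnccn23)cc(OC)c1OC`: 32000 nM
- Compound 2 `COc1ccc(Nc2c(-c3ccc(Cl)cc3)nc3cnccn23)cc1`: 45000 nM

Both numbers come from an ADME assay on Vero cells (Chlorocebus sabaeus) for cytotoxicity, read by MTT assay (a higher number here means that more compound is tolerated, a lower number that less compound is tolerated), and the read-out is the concentration lethal to half of the cells. The value of compound 1 lies within the usual scatter of the value of compound 2, so neither compound can be ranked above the other.

Compound 3 `COc1cc(Nc2c(C3C=Nc4ccccc43)nc3cnccn23)cc(OC)c1OC` keeps the core of compound 1 but loses the 4-chlorophenyl on an aromatic carbon of the five-membered aromatic ring: a group of 9 heavy atoms (8 carbon, 1 nitrogen; one five-membered non-aromatic ring with 1 hetero atom, one six-membered aromatic ring of carbon only) in place of a group of 7 heavy atoms (6 carbon, 1 chlorine; one six-membered aromatic ring of carbon only), on an aromatic carbon. Among the compounds with values here, no measured pair differing in one place exists to serve as a guide. A change in this assay beyond the scatter is therefore not expected, in either direction. The expected change is a 1.1-fold lower number from compound 1 to compound 3 (0.03 log units; within the scatter). The estimated value for compound 3 is 30000 nM, with an expected range of 10000 nM to 85000 nM.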

Compound 3, concentration lethal to 50% of the cells: 70000 nM
The estimate for compound 3 lay 2.3-fold (0.37 log units) below the measured number; the measured number falls inside the stated range.
By their numbers in this assay, from the lowest: compounds 1, 2 and 3 (each within the scatter of the next, the first and the last beyond it).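

Within the data shown here, replacing the 4-chlorophenyl with the group that carries a five-membered non-aromatic ring and a six-membered aromatic ring gives a 2.2-fold higher number from compound 1 to compound 3 (0.34 log units; beyond the scatter) in this assay and is the first step in this set to lie beyond the scatter. This position, on an aromatic carbon of the five-membered aromatic ring, can therefore change the number, and the 4-chlorophenyl can be exchanged here without a lower number resulting. Nothing measured here accounts for the rise.

With this single exchange, the ring nitrogen, the double bond and the extra heavy atoms of the new group cannot be told apart as the part that goes with the higher number. From the compounds shown here alone, whether an unsubstituted phenyl or a morpholine on the same carbon would give a similar number also stays open, as does the effect of the new group on compound 2.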